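Benzylic substituent changes on the shared core

The source may hold more compounds than are shown below. What is called first, only, known or untested is meant among the compounds shown, and "the series" means these compounds.

Measured so far:
Compound 1 `CCN1CCN(Cc2c(OC)cc(Oc3cccc(Nc4ccccc4)c3)cc2OC)CC1` gives > 20000 nM in a functional assay on HT-29 cells (Homo sapiens) for inhibition, read by MTT assay, with a stated time of 72 h; on this read-out higher numbers stand for weaker inhibition and lower numbers for stronger inhibition; that value is a limit of the assay, not a number.
Compound 2 `COc1cc(Oc2cccc(Nc3ccccc3)c2)cc(OC)c1CNC1CC1` gives 12300 nM in this assay.
Compound 3 `COc1cc(Oc2cccc(Nc3ccccc3)c2)cc(OC)c1CCO` gives 13900 nM in this assay.

Among the measured compounds shown here, compound 1 therefore stands only as a limit; where it sits on the scale is not fixed, and it is the single value of the three at that ceiling (the limit of > 20000 nM in this assay, at which 1 of the 3 values shown sits).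

Compound 4 `COc1cc(Oc2cccc(Nc3ccccc3)c2)cc(OC)c1CNCc1ccc(O)cc1` differs from compound 1 by (4-hydroxybenzyl)amino in place of 4-ethylpiperazin-1-yl on a saturated chain carbon bound to an aromatic carbon.

Two measured steps leave the same group from the same place. They read an at least 1.6-fold lower number from compound 1 to compound 2 (0.21 log units; that floor lies within the scatter) and an at least 1.4-fold lower number from compound 1 to compound 3 (0.15 log units; that floor lies within the scatter); both are floors only, because the limit of > 20000 nM in this assay, at which 1 of the 3 values shown sits, caps what compound 1 can show. Between the two replacements the gap is a 1.1-fold higher number from compound 2 to compound 3 (0.05 log units; within the scatter), so cyclopropylamino and hydroxymethyl land at the same level. Compound 4 carries a (4-hydroxybenzyl)amino group, another secondary amine on the saturated chain carbon bound to an aromatic carbon, like the cyclopropylamino of compound 2. The expected step in this assay is therefore a move off the limit down to about the level already reached because an at least 1.6-fold lower number from compound 1 to compound 2 (0.21 log units; that floor lies within the scatter) and an at least 1.4-fold lower number from compound 1 to compound 3 (0.15 log units; that floor lies within the scatter) show that drop, no larger, and is estimated as an at least 1.8-fold lower number from compound 1 to compound 4 (0.25 log units; that floor lies within the scatter).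

Compound 4 is expected near 11000 nM, with a range from 4000 nM to 30000 nM.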

Compound 4, half-maximal inhibitory concentration: 2180 nM
Estimate against measurement, compound 4: 5.0-fold (0.70 log units) above; the measured number lies below the stated range.
By their numbers in this assay, from the lowest: compound 4; then compounds 2 and 3 (each within the scatter of the next). At a limit, above all of these: compound 1.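

In this assay, among the compounds shown here, (4-hydroxybenzyl)amino is the first group on the saturated chain carbon bound to an aromatic carbon to move the series off the level shared by compound 2 and compound 3: the readings are a 6.4-fold lower number from compound 3 to compound 4 (0.80 log units; beyond the scatter) and a 5.6-fold lower number from compound 2 to compound 4 (0.75 log units; beyond the scatter). The second of these is the cleaner comparison, as both compounds carry a secondary amine and only the group on the amine nitrogen changes, so a secondary amine alone does not set the level in this pair. The reading against the piperazine compound is an at least 9.1-fold lower number from compound 1 to compound 4 (0.96 log units; beyond the scatter), but compound 1 is a limit and not a number, so this step is only a floor: the limit of > 20000 nM in this assay, at which 1 of the 4 values shown sits.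

Compound 4 brings in an aromatic ring and its hydroxyl together, and the compounds shown do not separate the two; a plain benzyl or a 4-methoxybenzyl group on the amine nitrogen would do so. They also leave open whether the length of the link from the amine nitrogen to the ring matters, which a 2-phenylethyl group there would test.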